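The source may report more compounds than this note shows. Statements on the series, on what has been measured and on what is new or still open speak of the compounds shown alone.

Compound 1, `Clc1cccc(Nc2ncnc3ccsc23)c1`, gives 50 nM in an assay for inhibition of acyl-CoA (8-3)-desaturase (Homo sapiens); a higher number here means a weaker inhibitor, a lower number a stronger inhibitor.
Compound 2, `Fc1ccc2[nH]nc(Nc3cccc(Cl)c3)c2c1`, gives 58 nM in this assay.

For the measured compounds named here, of the two numbers measured so far, compound 2 has the higher one, but its nearest neighbour is compound 1 and the gap between them is within the usual scatter of this assay, so the two compounds cannot be told apart on these data.

The next compound, compound 3, is `Cc1ccc2[nH]nc(Nc3cccc(Cl)c3)c2c1`. Compared with compound 2 the change is methyl in place of fluoro on an aromatic carbon: a single small, neutral group is exchanged for another of the same size at the same place on the shared core, with no ring, donor or acceptor added or lost. Going by the values given here, no measured pair shows what this exchange does. The expected step, a 1.0-fold higher number from compound 2 to compound 3 (0.01 log units; within the scatter), is therefore judged to stay within the scatter, in no particular direction. Compound 3 is expected to give 60 nM, with a likely range from 25 nM to 150 nM.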

Compound 3, half-maximal inhibitory concentration: 6 nM
Compound 3: the middle estimate sits 10-fold (1.00 log units) above what was measured; the whole stated range lies above it.
By their numbers in this assay, from the lowest: compound 3; then compounds 1 and 2 (each within the scatter of the next).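

For the compounds shown here, until now, only one group had been seen at this place on the shared core, so nothing showed whether a change here would matter in this assay. Methyl in place of fluoro gives a 9.7-fold lower number from compound 2 to compound 3 (0.99 log units; beyond the scatter), so exchanging one heavy atom for another, with no ring, hydrogen-bond donor, hydrogen-bond acceptor or net charge added or lost, is enough to move the number beyond the scatter. Nothing measured here accounts for the difference between these two groups.

As far as these compounds go, with only fluoro and methyl seen at this place, it remains open whether a longer chain such as ethyl would give a still lower number, or whether a methoxy group or an amine would keep the gain. Also open, from the compounds shown here alone, is whether methyl gives a similar step on other cores, such as that of compound 1.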